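A Benzyl Group Replaces Pyrimidin-2-yl on a Ring Nitrogen

The source may hold more compounds than are shown below. What is called first, only, known or untested is meant among the compounds shown, and "the series" means these compounds.

Compound 1, `CC(=O)N1CCN(c2nc(Nc3ccc(C#N)c(C(F)(F)F)c3)nc(Oc3ccnc4ccccc34)n2)CC1`, gives > 100000 nM in a functional assay on DU-145 cells (Homo sapiens) for cytotoxicity, read by sulforhodamine B assay, with a stated time of 48 h; a lower number here means a stronger inhibitor of growth, a higher number a weaker inhibitor of growth.
Compound 2, `CCN1CCN(c2nc(Nc3ccc(C#N)c(C(F)(F)F)c3)nc(Oc3ccnc4ccccc34)n2)CC1`, gives > 100000 nM in this assay.
Compound 3, `N#Cc1ccc(Nc2nc(Oc3ccnc4ccccc34)nc(N3CCN(c4ncccn4)CC3)n2)cc1C(F)(F)F`, gives > 100000 nM in this assay.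

Each of these three values is a limit of this assay, not a number; the assay did not reach a concentration at which growth stopped. Compound 3 therefore stands at the same limit as the other two, and no ordering among them can be read.

Compound 4, `N#Cc1ccc(Nc2nc(Oc3ccnc4ccccc34)nc(N3CCN(Cc4ccccc4)CC3)n2)cc1C(F)(F)F`, differs from compound 3 by one change: benzyl in place of pyrimidin-2-yl on an amine nitrogen in a ring.

The measured steps that touch the same ring nitrogen are a step that the two limits leave unreadable from compound 1 to compound 3 and a step that the two limits leave unreadable from compound 2 to compound 3; both are unreadable, since the two ends sit at the limit of > 100000 nM in this assay, at which 3 of the 3 values shown sit. The change to compound 4 also alters only the group on that ring nitrogen, so no readable step exists to set a direction in this assay.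

Compound 4 is expected to give about 100000 nM, with a range from 30000 nM to 300000 nM, and most likely again only as a limit. The expected step is estimated at a number no higher from compound 3 to compound 4 (the limit leaves the size open), not beyond the scatter.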

Compound 4, concentration for total growth inhibition: > 100000 nM
Compound 4: only a limit was reported; the forecaster's own chance of this, stated with the estimate: 70%; the middle value sits exactly at the limit.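

No new step can be read: compound 4 gives only a limit, so its steps from compound 1, compound 2 and compound 3 all stay unreadable, and the whole set sits at one place: the limit of > 100000 nM in this assay, at which 4 of the 4 values shown sit.

The compounds shown leave open whether any group on that ring nitrogen can make a difference in this assay.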